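Ortho hydroxy on the aniline ring of compound 3

The source may hold more compounds than are shown below. What is called first, only, known or untested is meant among the compounds shown, and "the series" means these compounds.

Measured so far in a functional assay on HUVEC cells (Homo sapiens), read by fluorescence and microscopy, with a stated time of 6 h, tested at 10 uM; a higher number here means a weaker effect of the compound at the concentration tested, a lower number a stronger effect:
- compound 1, `N#Cc1c(Nc2ccc([N+](=O)[O-])cc2)sc2ccccc12`, gives 8%
- compound 2, `COc1ccc(Nc2sc3ccccc3c2C#N)cc1`, gives 57%
- compound 3, `N#Cc1c(Nc2ccccc2)sc2ccccc12`, gives 81%

Compound 3 stands highest of the three numbers, beyond the scatter from both others: a number 24 percentage points higher from compound 2 to compound 3 (beyond the scatter), and a number 73 percentage points higher from compound 1 to compound 3 (beyond the scatter). Within this small set, every substituent placed on the aniline ring has lowered the number relative to the bare ring of compound 3, with a number 49 percentage points higher from compound 1 to compound 2 (beyond the scatter) showing that the size of the drop depends on which group enters.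

Compound 4, `N#Cc1c(Nc2ccccc2O)sc2ccccc12`, is the next step from compound 3: hydroxy in place of hydrogen on an aromatic carbon. Going by the values given here, no measured step covers a hydroxy group, nor a group on an aromatic carbon ortho to a large group, so the bearing steps are only the two that lower the number from compound 3 when a group enters the aniline ring, one modest and one large. A drop is therefore expected in this assay for compound 4, most likely of a size nearer the modest step, estimated as a number 21 percentage points lower from compound 3 to compound 4 (beyond the scatter). The expected value for compound 4 is 60%, within a range from 30% to 85%.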

Compound 4, a percentage reported as activity, at one concentration (the size of the read-out at that concentration, not a potency): 19%
For compound 4 the middle estimate is 41 percentage points above the measured one; the measured number lies below the stated range.
By their numbers in this assay, from the lowest: compound 1; then compound 4; then compound 2; then compound 3.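

In this assay, a single hydroxy on an aromatic carbon, ortho to a large group, gives a number 62 percentage points lower from compound 3 to compound 4 (beyond the scatter) as a large step, so one heavy atom at this place is enough to move the number far. Going by these compounds alone, neither compound 1 nor compound 2 carries a group at this place, so this is the first sign that the place itself can take a group with a large change in the read-out. Nothing in hand explains the size of this step.

Open, as far as these compounds go, is whether the step belongs to hydroxy specifically or to any group at this place, which an amine or a carboxylic acid there would help to separate. Also open, from the compounds shown here alone, is whether hydroxy on another carbon of the same ring would give a step of similar size.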